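A few compounds are considered here, and "the series" means these few. Any claim that something is new, unique, unknown or untested is made for them only; others in the source may bear on it.

In a functional assay on MCF7 cells (Homo sapiens) for antiproliferative activity (a higher number here means a weaker inhibitor of growth, a lower number a stronger inhibitor of growth), compound 1 `COc1ccc(-c2nc3ccccc3s2)cc1OC` gives 52700 nM. For the measured compounds named here, compound 2 `COc1ccc(-c2nc3c(F)cccc3s2)cc1OC` gives 5 nM, which leaves compound 1 with the higher of the two numbers measured so far, and so the weaker inhibitor of growth of the pair. Compound 3 `COc1ccc(-c2nc3cc(Br)ccc3s2)cc1OC` has not yet been measured. It departs from compound 1 by bromo in place of hydrogen on an aromatic carbon, with bromo in place of hydrogen on an aromatic carbon of the core.

Going by the values given here, only one measured step bears on this change, the swap of hydrogen for fluoro on an aromatic carbon, which gave an 11000-fold lower number from compound 1 to compound 2 (4.02 log units; beyond the scatter). That step is large and lies well beyond the scatter. It is a single precedent, though, and it involves a different group. Among the compounds with values here, the data contain no bromo compound against which to judge how much of the step carries over. Resting on compound 2 at 5 nM, a clear move towards a lower number is expected, but a smaller one than fluoro gave, and with wide uncertainty. The expected step is a 180-fold lower number from compound 1 to compound 3 (2.24 log units; beyond the scatter). For compound 3 the estimated value is 300 nM, within a range of 5 nM to 30000 nM.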

Compound 3, concentration for 50% growth inhibition: 13600 nM
Compound 3: the middle estimate sits 45-fold (1.66 log units) below what was measured, within the range that was stated.
By their numbers in this assay, from the lowest: compound 2; then compound 3; then compound 1.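

In this assay, bromo on a six-membered aromatic ring of carbon only, meta to a fused ring and para to a fused ring, gives a 3.9-fold lower number from compound 1 to compound 3 (0.59 log units; beyond the scatter), a modest step but one beyond the scatter. This shows that a second halogen also lowers the number on this ring of the shared core, but that replacing hydrogen here need not bring a step as large as an 11000-fold lower number from compound 1 to compound 2 (4.02 log units; beyond the scatter); compound 2 and compound 3 differ in both the group and the carbon that carries it, so the two steps cannot show whether the group, the place or both set their difference in size. No measurement shown here explains why either step has the size it does.

The compounds shown leave open how fluoro would behave on the carbon that carries bromo in compound 3, and how bromo would behave on the carbon that carries fluoro in compound 2. They also leave open what an amine or a carboxylic acid on the bromo-bearing carbon would do to the number in this assay.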